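Lengthening the phenyl tether in a leukotriene receptor series

The source may hold more compounds than are shown below. What is called first, only, known or untested is meant among the compounds shown, and "the series" means these compounds.

Compound 3 `O=C(O)CCC[C@H](O)[C@@H](/C=C\CCCCCCCCc1ccccc1)Sc1ccc(C(=O)O)cc1` holds the lowest number among the values measured in an assay on membranes from lung for binding affinity to cysteinyl leukotriene receptor 1 (Cavia porcellus) (a lower number here means a stronger inhibitor, a higher number a weaker inhibitor), where compound 3 gives 316 nM. Compound 2 `O=C(O)CCC[C@H](O)[C@@H](/C=C\CCCCCc1ccccc1)Sc1ccc(C(=O)O)cc1` gives 20000 nM in this assay. Compound 1 `O=C(O)CCC[C@H](O)[C@@H](/C=C/CCc1ccccc1)Sc1ccc(C(=O)O)cc1` reaches only a limit in this assay, < 100000 nM, which is a limit and not a number (the limit of < 100000 nM in this assay, at which 1 of the 3 values shown sits). Among the measured compounds shown here, the one measured step of this kind is a 63-fold lower number from compound 2 to compound 3 (1.80 log units; beyond the scatter). Compound 4 `O=C(O)CCC[C@H](O)[C@@H](/C=C\CCCCCCCCCc1ccccc1)Sc1ccc(C(=O)O)cc1` differs from compound 3 by benzyl in place of phenyl on a saturated chain carbon, eight bonds along the chain from a double-bonded chain carbon, a smaller extension of the same tether. Because the earlier extension a 63-fold lower number from compound 2 to compound 3 (1.80 log units; beyond the scatter) was large, a further lowering is expected, though a modest one, estimated as a 2.0-fold lower number from compound 3 to compound 4 (0.30 log units; within the scatter). Compound 4 is therefore expected to give 160 nM in this assay, estimated between 50 nM and 800 nM.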

Compound 4, inhibition constant: 251 nM
Beside the measured number, compound 4's estimate is 1.6-fold (0.20 log units) below it, within the range that was stated.
By their numbers in this assay, from the lowest: compounds 4 and 3 (each within the scatter of the next); then compound 2.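

In this assay, benzyl in place of phenyl, eight bonds along the chain from a double-bonded chain carbon, gives a 1.3-fold lower number from compound 3 to compound 4 (0.10 log units; within the scatter) and so the steep response to lengthening does not carry on through this change. The whole extension to 4-phenylbutyl amounts to an 80-fold lower number from compound 2 to compound 4 (1.90 log units; beyond the scatter) and most of that is already reached in compound 3. On these data alone, whether a longer chain keeps this level remains open, as does the effect of an amine or a carboxylic acid in place of the phenyl. Nothing shown accounts for the levelling.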